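This account rests on a few compounds, and the source may have more. Where it says the series, first, only, none or still open, it means among the compounds named here.

Measured compounds in an assay on isolated protein for inhibition of Thymidylate synthase (Homo sapiens); a lower number here means a stronger inhibitor, a higher number a weaker inhibitor:
- compound 1 `N=c1scc(-c2ccccc2)n1CC(=O)N1CCOCC1`: 6220 nM
- compound 2 `CN1CCN(C(=O)Cn2c(-c3ccccc3)csc2=N)CC1`: 1140 nM
- compound 3 `CC(=O)N1CCN(C(=O)Cn2c(-c3ccc(C)cc3)csc2=N)CC1`: 3650 nM

Compound 1 gives the highest of the three numbers in this assay. Compound 3 is nearest to it, and its number and that of compound 1 lie within the scatter of each other, so no order between them can be read. Within the data shown here, compound 2 is furthest; the one step that is fully resolved, a 5.5-fold lower number from compound 1 to compound 2 (0.74 log units; beyond the scatter), is a change at the carbonyl carbon and not at the phenyl ring.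

Compound 4 `Cc1ccc(-c2csc(=N)n2CC(=O)N2CCOCC2)cc1` is not yet measured. Against compound 1 it shows (methyl in place of hydrogen on an aromatic carbon); seen one bond further out, phenyl becomes 4-methylphenyl. Among the measured compounds shown here, no measured step concerns this methyl in isolation. Compound 3 carries the same 4-methylphenyl but also an acetylpiperazine, so only its two values with compound 2 can be set side by side, and they differ in two places. The only reference point of a methylphenyl compound, compound 3, sits within the scatter of compound 1, which gives no ground to expect a shift beyond the scatter. Compound 4 is therefore expected to come out near compound 1, with an expected step of a 1.2-fold lower number from compound 1 to compound 4 (0.09 log units; within the scatter). The estimate for compound 4 is 5000 nM, within 2000 nM to 15000 nM.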

Compound 4, inhibition constant: 4060 nM
Compound 4: middle estimate off by 1.2-fold (0.09 log units), on the high side, within the range that was stated.
By their numbers in this assay, from the lowest: compound 2; then compounds 3, 4 and 1 (each within the scatter of the next).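

In this assay, methyl in place of hydrogen on an aromatic carbon para to a large group gives a 1.5-fold lower number from compound 1 to compound 4 (0.19 log units; within the scatter), so phenyl and 4-methylphenyl cannot be told apart when the carbonyl carbon carries morpholin-4-yl. Among these compounds, this is the first single-place reading at the phenyl ring, and it shows that this position accepts a methyl without a resolved shift, whereas the one resolved step, a 5.5-fold lower number from compound 1 to compound 2 (0.74 log units; beyond the scatter), lies at the carbonyl carbon. Nothing available bears on the reason for this result.

The compounds shown leave open whether the methyl also reads as flat with 4-methylpiperazin-1-yl on the carbonyl carbon, as in compound 2. They also leave open how a chlorine, a methoxy group or a carboxylic acid would read at this ring position.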